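A Pyridin-2-yl Hydrazone Awaiting Its Dose

A few compounds are considered here, and "the series" means these few. Any claim that something is new, unique, unknown or untested is made for them only; others in the source may bear on it.

compound 1 `CC1CCC(=NNc2c(Cl)cccc2Cl)c2ncc(C(=O)O)c(=O)n21`: in a functional assay on the whole organism with Rattus norvegicus as the target (on this read-out lower numbers stand for an effect already at smaller amounts and higher numbers for an effect only at larger amounts of compound), compound 1 gives > 100 umol/kg, a limit of the assay.
compound 2 `CC1CCC(=NNc2cc(Cl)ccc2O)c2ncc(C(=O)O)c(=O)n21`: in this assay compound 2 gives > 100 umol/kg, a limit of the assay.

The step that the two limits leave unreadable from compound 1 to compound 2 therefore cannot be sized. Compound 2 stands only at a limit, and both values shown sit at the limit of > 100 umol/kg in this assay, at which 2 of the 2 values shown sit. Compound 3 `CC1CCC(=NNc2ccccn2)c2ncc(C(=O)O)c(=O)n21` differs from compound 2 by pyridin-2-yl in place of 5-chloro-2-hydroxyphenyl on an amine nitrogen. Among the compounds with values here, no measured step reaches past the limit, so no size of step in this assay can be read from them. The step is expected as a step that the limit leaves unreadable from compound 2 to compound 3, with a wide range. Compound 3 is therefore estimated at 150 umol/kg, between 30 umol/kg and 1000 umol/kg.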

Compound 3, dose for 50% inhibition: > 100 umol/kg
Compound 3: only a limit was reported (the forecaster's own chance of this, stated with the estimate: 70%); the middle value lies beyond the limit too.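

Within the data shown here, compound 3 joins compound 1 and compound 2 at the same limit of the assay, so no step among the three can be read: the limit of > 100 umol/kg in this assay, at which 3 of the 3 values shown sit. The compounds shown leave open how far past that limit each one lies in this assay and whether the groups on the amine nitrogen differ at all.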